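Swapping phenyl for benzyl on a hydroxamic acid inhibitor

A few compounds are considered here, and "the series" means these few. Any claim that something is new, unique, unknown or untested is made for them only; others in the source may bear on it.

Measured compounds:
- compound 1 `O=C(/C=C/c1cccc(CSc2nc(O)cc(-c3ccccc3)n2)c1)NO`: 57 nM
- compound 2 `CC(c1ccccc1)c1cc(O)nc(SCCCCCC(=O)NO)n1`: 121 nM

In an assay on isolated protein for inhibition of histone deacetylase 1 (Mus musculus) (on this read-out lower numbers stand for stronger inhibition and higher numbers for weaker inhibition), compound 1 gives 57 nM, and compound 2 gives 121 nM. Compound 1 thus holds the lowest number of the two, and its gap to compound 2 is beyond the usual scatter of repeated runs. The two compounds share a core but differ in several places at once, so no single change can be read from that pair.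

Compound 3 `O=C(/C=C/c1cccc(CSc2nc(O)cc(Cc3ccccc3)n2)c1)NO` has not yet been tested. It differs from compound 1 by a single change: benzyl in place of phenyl on an aromatic carbon. The hydroxamic acid end and the rest of the molecule stay as they are. Within the data shown here, nothing among the measured compounds tracks this exact change, so the step in this assay is unknown. A modest shift, likely no larger than the scatter, is expected from compound 1 to compound 3, a 1.2-fold higher number from compound 1 to compound 3 (0.09 log units; within the scatter). Compound 3 is therefore estimated at 70 nM, within a range of 25 nM to 200 nM.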

Compound 3, half-maximal inhibitory concentration: 90 nM
Compound 3: the middle estimate sits 1.3-fold (0.11 log units) below what was measured; measured number inside the range.
By their numbers in this assay, from the lowest: compounds 1, 3 and 2 (each within the scatter of the next, the first and the last beyond it).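

In this assay, benzyl in place of phenyl on this aromatic carbon gives a 1.6-fold higher number from compound 1 to compound 3 (0.20 log units; within the scatter). Among these compounds, this is the first comparison here that isolates one change, as compound 1 and compound 2 differ in several places at once, and it shows that this position, next to the ring nitrogen, takes benzyl, with 7 heavy atoms rather than 6, without a shift beyond the scatter. No measured evidence is available to explain this result.

From the compounds shown here alone, how far this tolerance extends remains open, since an amine, a carboxylic acid or a longer chain ending in phenyl at this position could give quite a different number. It is also unknown whether the same swap would give a similar step on another linker to the hydroxamic acid, such as the straight chain of compound 2.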